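The source may report more compounds than this note shows. Statements on the series, on what has been measured and on what is new or still open speak of the compounds shown alone.

Compound 1 `Cn1cncc1CN1CC(N(CC2CCN(C(=O)C3CCCC3)CC2)S(=O)(=O)c2ccccn2)Cc2cc(C#N)ccc21` gives 0.5 10^-6 cm/s in an ADME assay on Caco-2 cells (Homo sapiens) for permeability, in the apical to basolateral direction; a higher number here means that the compound crosses the layer faster, a lower number that the compound crosses the layer more slowly. Compound 3 `CCCC(=O)N1CCC(CN(C2Cc3cc(C#N)ccc3N(Cc3cncn3C)C2)S(=O)(=O)c2ccccn2)CC1` gives 0.5 10^-6 cm/s in this assay, and the two stand level, together the lowest of the three numbers. Compound 2 `Cn1cncc1CN1CC(N(Cc2cccc(-n3cccc3)c2)S(=O)(=O)c2ccccn2)Cc2cc(C#N)ccc21` gives 2.3 10^-6 cm/s in this assay, the highest of the three, the step being a 4.6-fold lower number from compound 2 to compound 3 (0.66 log units; beyond the scatter). Compound 4 `CC(=O)N1CCC(CN(C2Cc3cc(C#N)ccc3N(Cc3cncn3C)C2)S(=O)(=O)c2ccccn2)CC1` differs from compound 1 by methyl in place of cyclopentyl on a carbonyl carbon. The step that bears on this is no change at the digits printed from compound 1 to compound 3 (within the scatter), where the same carbonyl substituent was changed without effect on the number. Since cutting the group further, to methyl, is a change of the same kind, compound 4 is expected to show no change at the digits printed from compound 1 to compound 4 (within the scatter), that is, nothing beyond the scatter. Compound 4 is therefore estimated at 0.5 10^-6 cm/s, within 0.25 10^-6 cm/s to 1 10^-6 cm/s.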

Compound 4, apparent permeability: 0.5 10^-6 cm/s
Estimate against measurement, compound 4: no gap at the digits printed, within the range that was stated.
By their numbers in this assay, from the lowest: compounds 1, 3 and 4 (each within the scatter of the next); then compound 2.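

On the carbonyl carbon, methyl now joins propyl and cyclopentyl as a group that leaves the number unmoved, with no change at the digits printed from compound 1 to compound 4 (within the scatter) and no change at the digits printed from compound 3 to compound 4 (within the scatter) in this assay. The 3-(1H-pyrrol-1-yl)phenyl group on the saturated chain carbon bound to a sulfonamide nitrogen still separates from the acetyl-bearing piperidine, with a 4.6-fold lower number from compound 2 to compound 4 (0.66 log units; beyond the scatter). Nothing at hand gives a reason for either result. Still open is whether a carbonyl substituent carrying an amine or a carboxylic acid would shift the number, since only plain carbon groups are shown there.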